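Bromine shift on the benzyl ring: 3-bromo to 2-bromo

This account rests on a few compounds, and the source may have more. Where it says the series, first, only, none or still open, it means among the compounds named here.

Measured in a functional assay on A-375 cells (Homo sapiens) for antiproliferative activity, read by MTT assay, with a stated time of 24 h; on this read-out higher numbers stand for weaker inhibition and lower numbers for stronger inhibition:
- compound 1 `COc1cc(OC)c(-c2coc3cc(OCc4ccc(F)cc4)ccc3c2=O)cc1OC`: 1720 nM
- compound 2 `COc1cc(OC)c(-c2coc3cc(OCc4cccc(F)c4)ccc3c2=O)cc1OC`: 1300 nM
- compound 3 `COc1cc(OC)c(-c2coc3cc(OCc4cccc(Br)c4)ccc3c2=O)cc1OC`: 1120 nM

Compound 3 stands level with both neighbours, as a 1.2-fold lower number from compound 2 to compound 3 (0.06 log units; within the scatter) and a 1.5-fold lower number from compound 1 to compound 3 (0.19 log units; within the scatter) show. Compound 4 `COc1cc(OC)c(-c2coc3cc(OCc4ccccc4Br)ccc3c2=O)cc1OC` has 2-bromophenyl in place of 3-bromophenyl on a saturated chain carbon bound to an oxygen on an aromatic ring. For the measured compounds named here, the nearest precedent is the shift of fluoro between compounds, a 1.3-fold lower number from compound 1 to compound 2 (0.12 log units; within the scatter), which also stayed small. Going by the values given here, no measured compound carries a 2-substituted phenyl, so this placement remains untested. No step beyond the scatter is expected in this assay, and the estimated step is a 1.2-fold higher number from compound 3 to compound 4 (0.06 log units; within the scatter). For compound 4 the expected value is 1300 nM, with an estimated range of 700 nM to 2400 nM.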

Compound 4, half-maximal inhibitory concentration: 2850 nM
Compound 4: the middle estimate sits 2.2-fold (0.34 log units) below what was measured; measured number above the stated range.
By their numbers in this assay, from the lowest: compounds 3, 2, 1 and 4 (each within the scatter of the next, the first and the last beyond it).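

In this assay, for the compounds shown here, moving bromo on the benzyl ring gives the first step beyond the scatter (a 2.5-fold higher number from compound 3 to compound 4 (0.41 log units; beyond the scatter)). The 2-bromophenyl group also separates from 3-fluorophenyl (a 2.2-fold higher number from compound 2 to compound 4 (0.34 log units; beyond the scatter)) but not from 4-fluorophenyl (a 1.7-fold higher number from compound 1 to compound 4 (0.22 log units; within the scatter)), so the placement of the halogen on this ring can matter here, though modestly and not against every compound. Nothing available accounts for the shift. Open, going by these compounds, is whether 2-chlorophenyl or 2-fluorophenyl would track compound 4, and where unsubstituted phenyl would fall on this chain carbon.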